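Fluoro for carboxy on the sulfonyl aryl of compound 1

The source may report more compounds than this note shows. Statements on the series, on what has been measured and on what is new or still open speak of the compounds shown alone.

Measured compounds:
compound 1 `Cn1c(=O)c(S(=O)(=O)c2ccc(C(=O)O)cc2)cc2cnc(Nc3ccc4[nH]ccc4c3)nc21`: 5000 nM
compound 2 `COc1ccc(Nc2ncc3cc(S(=O)(=O)c4ccc(C)cc4)c(=O)n(C)c3n2)cc1`: 75000 nM
compound 3 `Cn1c(=O)c(S(=O)(=O)c2ccccc2)cc2cnc(Nc3ccc4ncccc4c3)nc21`: 100000 nM

In a functional assay on K562 cells (Homo sapiens) for inhibition, read by trypan blue exclusion, with a stated time of 72 h (on this read-out higher numbers stand for weaker inhibition and lower numbers for stronger inhibition), compound 1 gives 5000 nM, the lowest of the three numbers. Compound 2 gives 75000 nM and compound 3 gives 100000 nM; both stand well beyond the scatter from compound 1, though each differs from it in more than one place, so no single change can be read from them.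

Compound 4 `Cn1c(=O)c(S(=O)(=O)c2ccc(F)cc2)cc2cnc(Nc3ccc4[nH]ccc4c3)nc21` keeps the core and the indole of compound 1 and changes only the sulfonyl aryl ring: fluoro in place of carboxy on an aromatic carbon. For the measured compounds named here, no pair of measured compounds isolates this change, and compounds 2 and 3 carry neither the carboxy nor the indole, so they give no guide to its size. Without such a step, the estimate for compound 4 is a modest weakening, with a wide range on either side, expected as a 3.0-fold higher number from compound 1 to compound 4 (0.48 log units; beyond the scatter). Compound 4 is therefore expected to give about 15000 nM in this assay , between 4000 nM and 60000 nM.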

Compound 4, half-maximal inhibitory concentration: 200 nM
For compound 4 the middle estimate is 75-fold (1.88 log units) above the measured one; the measured number lies below the stated range.
By their numbers in this assay, from the lowest: compound 4; then compound 1; then compounds 2 and 3 (each within the scatter of the next).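

For the compounds shown here, the step of a 25-fold lower number from compound 1 to compound 4 (1.40 log units; beyond the scatter) is the only single-place comparison in this assay, and it is large. It shows that the group on the sulfonyl aryl ring, para to a large group, strongly affects the read-out: with the core and the indole unchanged, fluoro in place of carboxy gives much stronger inhibition, well beyond the scatter. No data shown here bear on why the number falls.

Compounds 2 and 3 differ from compound 4 in more than one place, so the compounds shown do not tell whether the gain comes from adding fluoro or from losing carboxy. Also open, as far as these compounds go, is how the indole-bearing compound would respond to chloro, an amine or a primary amide at this position.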